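The source may report more compounds than this note shows. Statements on the series, on what has been measured and on what is new or still open speak of the compounds shown alone.

Cytotoxicity series, read in an ADME assay on MCF-10A cells (Homo sapiens) for cytotoxicity, read by MTT assay, with a stated time of 48 h; on this read-out lower numbers stand for stronger inhibition and higher numbers for weaker inhibition:
compound 1 `COc1cc2cc(C(=O)NCCCc3ccccc3)c(=O)oc2cc1OCCCOc1no[n+]([O-])c1S(=O)(=O)c1ccccc1` gives 5330 nM
compound 2 `COc1ccc(NC(=O)c2cc3cc(OC)c(OCCCOc4no[n+]([O-])c4S(=O)(=O)c4ccccc4)cc3oc2=O)cc1` gives 5470 nM
compound 3 `COc1cc2cc(C(=O)NCc3ccccc3)c(=O)oc2cc1OCCCOc1no[n+]([O-])c1S(=O)(=O)c1ccccc1` gives 7030 nM

Compound 3 returns the highest of the three numbers, yet its nearest neighbour is compound 2 at a 1.3-fold higher number from compound 2 to compound 3 (0.11 log units; within the scatter), and the step of a 1.3-fold higher number from compound 1 to compound 3 (0.12 log units; within the scatter) is no larger; the three values all lie within the scatter of one another, so no order among them is read.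

Compound 4 `COc1cc2cc(C(=O)Nc3ccc(F)cc3)c(=O)oc2cc1OCCCOc1no[n+]([O-])c1S(=O)(=O)c1ccccc1` differs from compound 3 by 4-fluorophenyl in place of benzyl on an amide-type nitrogen. Going by the values given here, the steps that bear on this are the two that change the group on the same amide-type nitrogen: a 1.0-fold higher number from compound 1 to compound 2 (0.01 log units; within the scatter) and a 1.3-fold higher number from compound 2 to compound 3 (0.11 log units; within the scatter). Both stayed within the scatter, and compound 1 against compound 3, a 1.3-fold higher number from compound 1 to compound 3 (0.12 log units; within the scatter), shows the same. Nothing among the three measured amides has moved the number beyond the scatter, so compound 4 is expected in this assay to show a step of a 1.2-fold lower number from compound 3 to compound 4 (0.07 log units; within the scatter), that is, none beyond the scatter. Compound 4 is estimated at 6000 nM, with a range of 3000 nM to 12000 nM.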

Compound 4, half-maximal inhibitory concentration: 7210 nM
The estimate for compound 4 lay 1.2-fold (0.08 log units) below the measured number; the measured number falls inside the stated range.
By their numbers in this assay, from the lowest: compounds 1, 2, 3 and 4 (each within the scatter of the next).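

In this assay, going by these compounds alone, the swap on the amide-type nitrogen from benzyl to 4-fluorophenyl, with the same heavy-atom count entering and leaving, gives a step within the scatter (a 1.0-fold higher number from compound 3 to compound 4 (0.01 log units; within the scatter)), and this is the first fluoro group at this position. The comparison with the methoxy analogue, fluoro in place of methoxy on an aromatic carbon (a 1.3-fold higher number from compound 2 to compound 4 (0.12 log units; within the scatter)), and the comparison with the 3-phenylpropyl amide (a 1.4-fold higher number from compound 1 to compound 4 (0.13 log units; within the scatter)) also stay within the scatter, so all four amides in this series, with aryl or arylalkyl groups on that nitrogen, read alike in this assay. No supporting measurement accompanies these numbers to account for this.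

On these data alone, whether an amine or a carboxylic acid on the aromatic ring of the amide group, or a longer chain in its place, would give a step beyond the scatter remains open. As far as these compounds go, the core, the phenylsulfonyl group and the chain joining them are the same in all four compounds, so what each of these parts contributes to the number also remains open.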